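A Hydroxycarbamoyl Chain Exchanged on the Shared Core

The source may report more compounds than this note shows. Statements on the series, on what has been measured and on what is new or still open speak of the compounds shown alone.

In a functional assay on HeLa cells (Homo sapiens) for inhibition, read by MTT assay, with a stated time of 48 h (on this read-out lower numbers stand for stronger inhibition and higher numbers for weaker inhibition), compound 1 (`O=S(=O)(c1ccccc1)c1c(OCCCCCCO)no[n+]1[O-]`) has the entry "not determined" (no result reported) and offers no number for comparison. Compound 2 (`O=C(CCCOc1no[n+]([O-])c1S(=O)(=O)c1ccccc1)NO`) gives 4790 nM and compound 3 (`O=C(CCCCCCCOc1no[n+]([O-])c1S(=O)(=O)c1ccccc1)NO`) gives 5030 nM and so stands level with compound 2 within the scatter. Compound 4 (`O=C(NO)OCCOCCOc1no[n+]([O-])c1S(=O)(=O)c1ccccc1`) awaits measurement. It carries 2-((hydroxycarbamoyl)oxy)ethoxy in place of 5-(hydroxycarbamoyl)pentyl on a saturated chain carbon, two bonds along the chain from an oxygen on an aromatic ring. Among the compounds with values here, the one measured step bearing on this is a chain change (a 1.1-fold higher number from compound 2 to compound 3 (0.02 log units; within the scatter)), so no shift beyond the scatter is expected in this assay, although no measured compound carries the new group. The expected step is small (a 1.0-fold lower number from compound 3 to compound 4 (0.00 log units; within the scatter)). Compound 4 is estimated at 5000 nM within a range from 2200 nM to 11000 nM for now.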

Compound 4, half-maximal inhibitory concentration: 5140 nM
Compound 4: the middle estimate sits 1.0-fold (0.01 log units) below what was measured; the measured number falls inside the stated range.
By their numbers in this assay, from the lowest: compounds 2, 3 and 4 (each within the scatter of the next).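

In this assay, 2-((hydroxycarbamoyl)oxy)ethoxy in place of 5-(hydroxycarbamoyl)pentyl gives (a 1.0-fold higher number from compound 3 to compound 4 (0.01 log units; within the scatter)), and the same group in place of (hydroxycarbamoyl)methyl gives (a 1.1-fold higher number from compound 2 to compound 4 (0.03 log units; within the scatter)). At this position, then, a change in the make-up of the chain, with oxygen atoms entering it, leaves the number within the scatter, as the change of chain length alone did. Nothing available explains this level result. As far as these compounds go, whether a carboxylic acid or an amine in place of the hydroxycarbamoyl end would move the number remains open.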